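A Spirohydantoin Series: Trimming the Piperidine Side Chain

A few compounds are considered here, and "the series" means these few. Any claim that something is new, unique, unknown or untested is made for them only; others in the source may bear on it.

Measured compounds:
- compound 1, `CC(C)(C)OC(=O)NCCCCNC(=O)CN1CN(c2ccccc2)C2(CCN(C(=O)c3ccc(C(C)(C)C)cc3)CC2)C1=O`: "not determined" (no result reported)
- compound 2, `CC(C)(C)OC(=O)NCCCNC(=O)CN1CN(c2ccccc2)C2(CCN(C(=O)c3ccc(C(C)(C)C)cc3)CC2)C1=O`: 4500 nM
- compound 3, `CC(C)(C)OC(=O)NCC1CCCN(C(=O)CN2CN(c3ccccc3)C3(CCN(C(=O)c4ccc(C5CCCCC5)cc4)CC3)C2=O)C1`: 3800 nM

Three compounds share one core and differ in the amide-bound tail and in the group on the benzoyl ring. In an assay on HEK293 cells for displacement of a labelled ligand from NPC1-like intracellular cholesterol transporter 1 (Homo sapiens) (on this read-out lower numbers stand for stronger inhibition and higher numbers for weaker inhibition), compound 2 gives 4500 nM and compound 3 gives 3800 nM. Compound 3 holds the lowest of the two numbers, but compound 2 stands within the scatter of it, so the two values cannot be told apart. For compound 1 no number was reported.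

Compound 4, `O=C(CN1CN(c2ccccc2)C2(CCN(C(=O)c3ccc(C4CCCCC4)cc3)CC2)C1=O)N1CCCCC1`, is the next member. It differs from compound 3 in one place: hydrogen in place of ((tert-butoxycarbonyl)amino)methyl on a saturated ring carbon. The whole tert-butoxycarbonyl-protected amine is thus removed and the six-membered nitrogen ring is left bare. For the measured compounds named here, no pair among the measured compounds shows what such a removal does, so the direction of the step in this assay is open; the two measured values suggest that the tail has little influence here, and a step no larger than the scatter, or a modest weakening, seems the more likely outcome. Compound 4 is therefore estimated at 6000 nM, with a range from 2000 nM to 20000 nM, which would mean an expected step of a 1.6-fold higher number from compound 3 to compound 4 (0.20 log units; within the scatter).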

Compound 4, half-maximal inhibitory concentration: 1100 nM
For compound 4 the middle estimate is 5.5-fold (0.74 log units) above the measured one; the measured number lies below the stated range.
By their numbers in this assay, from the lowest: compound 4; then compounds 3 and 2 (each within the scatter of the next).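

In this assay, replacing ((tert-butoxycarbonyl)amino)methyl with hydrogen on the saturated ring carbon, two ring bonds from the ring nitrogen, gives a 3.5-fold lower number from compound 3 to compound 4 (0.54 log units; beyond the scatter). Compounds 2 and 3 differ in more than one place and could not isolate any single change, whereas this pair shows that the substituent at this position affects the read-out and that the protected amine side chain is not needed to reach the lower number, since the bare ring gives the stronger inhibition of the two. Nothing measured here accounts for the step, and no data separate the contribution of the tert-butoxycarbonyl part from that of the rest of the departing group.

On these data alone, the whole group left in a single step, so it remains open whether a free aminomethyl group, a methyl group or a hydroxyl group on the same ring carbon would give a number closer to that of compound 3 or of compound 4. As far as these compounds go, it is also open whether the same removal would give a step of similar size with tert-butyl in place of cyclohexyl on the benzoyl ring.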